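Amine substituent exchange on the trifluoromethylphenyl piperazine series

This account rests on a few compounds, and the source may have more. Where it says the series, first, only, none or still open, it means among the compounds named here.

Measured compounds:
compound 1, `CCC(C)[C@H](N)c1cc(C(F)(F)F)ccc1N1CCN(C(=O)CCc2ccc(Cl)cc2)CC1`, gives 86 nM in this assay.
compound 2, `CC(C)C[C@H](N)c1cc(C(F)(F)F)ccc1N1CCN(C(=O)CCc2ccc(O)cc2)CC1`, gives > 10000 nM; this is a limit of the assay, not a number.
compound 3, `CCC(C)[C@H](NCC1CCCO1)c1cc(C(F)(F)F)ccc1N1CCN(C(=O)CCc2ccc(Cl)cc2Cl)CC1`, gives 780 nM.

In an assay on HEK293 cells for displacement of a labelled ligand from Melanocortin receptor 4 (Homo sapiens) (on this read-out lower numbers stand for stronger inhibition and higher numbers for weaker inhibition), compound 3 stands at the higher of the two numbers; compound 1 gives the lower one, and the gap between them lies beyond the scatter. For compound 2 only the limit of > 10000 nM in this assay, at which 1 of the 3 values shown sits, is available. Compound 4, `COCCN[C@@H](CC(C)C)c1cc(C(F)(F)F)ccc1N1CCN(C(=O)CCc2ccc(Cl)cc2Cl)CC1`, is not yet measured. It differs from compound 3 in one place: 1-((2-methoxyethyl)amino)-3-methylbutyl in place of 2-methyl-1-(((oxolan-2-yl)methyl)amino)butyl on an aromatic carbon. Among the compounds with values here, no measured step covers this change, so the expectation rests on compound 3 alone. The step is expected to be small, within the scatter or barely beyond it, toward a lower number: a 1.6-fold lower number from compound 3 to compound 4 (0.19 log units; within the scatter). Compound 4 is estimated at 500 nM, with a range from 120 nM to 2500 nM.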

Compound 4, inhibition constant: 620 nM
The estimate for compound 4 lay 1.2-fold (0.09 log units) below the measured number, within the range that was stated.
By their numbers in this assay, from the lowest: compound 1; then compounds 4 and 3 (each within the scatter of the next). At a limit, above all of these: compound 2.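

In this assay, replacing 2-methyl-1-(((oxolan-2-yl)methyl)amino)butyl with 1-((2-methoxyethyl)amino)-3-methylbutyl gives a 1.3-fold lower number from compound 3 to compound 4 (0.10 log units; within the scatter). This first single-place pair in the series shows that, at this aromatic carbon, the open-chain group without a ring reads the same as the ring-bearing group within the scatter. No measurement shown gives a cause for this step. Still open, as far as these compounds go, is how a longer ether chain or a carboxylic acid on this amine nitrogen would read. The separate contributions of the ring and of the alkyl branch also remain unresolved, since both change together here.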